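Moving the hydroxyl around the flanking aryl ring

The source may hold more compounds than are shown below. What is called first, only, known or untested is meant among the compounds shown, and "the series" means these compounds.

In an assay on isolated protein for inhibition of DNA topoisomerase 1 (Homo sapiens), with a stated time of 30 min, tested at 100 uM (on this read-out higher numbers stand for more inhibition at the one concentration tested (going by the name of the read-out) and lower numbers for less inhibition), compound 2 `Oc1ccccc1-c1cc(-c2ccccc2O)nc(-c2ccccc2O)c1` gives 0%, the lowest of the two numbers shown, though within the scatter of compound 1 `Oc1cccc(-c2cc(-c3ccccc3O)nc(-c3ccccc3O)c2)c1`, which gives 4.9%. Among the measured compounds shown here, the one measured step, a number 4.9 percentage points lower from compound 1 to compound 2 (within the scatter), stayed within the scatter. Compound 3 `Oc1ccc(-c2cc(-c3ccccc3O)nc(-c3ccccc3O)c2)cc1` differs from compound 2 in one place: 4-hydroxyphenyl in place of 2-hydroxyphenyl on an aromatic carbon. Since the related change from compound 1 to compound 2 produced nothing beyond the scatter, no step beyond the scatter is expected here either. Compound 3 is therefore expected to give 3%, with a range from 0% to 15%. The expected step of a number 3 percentage points higher from compound 2 to compound 3 (within the scatter) lies within the scatter.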

Compound 3, a percentage reported as inhibition, at one concentration (the size of the read-out at that concentration, not a potency): 3.7%
Estimate against measurement, compound 3: 0.7 percentage points below; measured number inside the range.
By their numbers in this assay, from the lowest: compounds 2, 3 and 1 (each within the scatter of the next).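

With 4-hydroxyphenyl, the 2-, 3- and 4-hydroxyphenyl groups at the place opposite the ring nitrogen have all been read in this assay. The change to 4-hydroxyphenyl gives a number 3.7 percentage points higher from compound 2 to compound 3 (within the scatter) and a number 1.2 percentage points lower from compound 1 to compound 3 (within the scatter) and so separates none of the three, which means that moving the hydroxyl around this ring gives no difference that can be told apart in these compounds. No evidence is available that bears on this result.

As far as these compounds go, whether an amine or a carboxylic acid on this ring in place of the hydroxyl would move the number beyond the scatter remains open. So does the effect of replacing the two 2-hydroxyphenyl groups.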